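The source may report more compounds than this note shows. Statements on the series, on what has been measured and on what is new or still open speak of the compounds shown alone.

Compound 2 `O=[N+]([O-])c1c(CS(=O)(=O)c2ccccc2)nc2c(-c3ccc(O)cc3)cc(Cl)cn12` carries a nitro group and a phenylsulfonylmethyl group on a shared core, with a 4-hydroxyphenyl on an aromatic carbon. In an ADME assay on HepG2 cells (Homo sapiens) for cytotoxicity, read by MTT assay, with a stated time of 72 h (a higher number here means that more compound is tolerated, a lower number that less compound is tolerated), compound 2 gives > 12500 nM, which is a limit of the assay rather than a number. Compound 1 `O=[N+]([O-])c1c(CS(=O)(=O)c2ccccc2)nc2c(-c3ccc(Cl)cc3)cc(Cl)cn12` gives > 3900 nM in this assay, again a limit. Compound 3 `O=[N+]([O-])c1c(CS(=O)(=O)c2ccccc2)nc2c(-c3ccccc3F)cc(Cl)cn12` gives > 3900 nM in this assay, also a limit. Compound 2 therefore stands only at a limit, as do the other two values shown; one value sits at the limit of > 12500 nM in this assay, at which 1 of the 3 values shown sits, and two sit at the limit of > 3900 nM in this assay, at which 2 of the 3 values shown sit.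

Compound 4 `O=[N+]([O-])c1c(CS(=O)(=O)c2ccccc2)nc2c(-c3cccnc3)cc(Cl)cn12` differs from compound 2 in one place: pyridin-3-yl in place of 4-hydroxyphenyl on an aromatic carbon. The measured steps that touch compound 2 are a step that the two limits leave unreadable from compound 1 to compound 2 and a step that the two limits leave unreadable from compound 2 to compound 3, and both are left unreadable by the limits, so no size or direction can be taken from them. The step from compound 2 to compound 4 is therefore expected to be an at least 1.2-fold lower number from compound 2 to compound 4 (0.09 log units; that floor lies within the scatter), which means no change that can be told apart from the scatter. Compound 4 is expected to give about 10000 nM in this assay, within a range from 3000 nM to 40000 nM, most likely reported once more as a limit.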

Compound 4, half-maximal cytotoxic concentration: > 31300 nM
Compound 4: no number, only a limit (the forecaster's own chance of this, stated with the estimate: 85%); middle value at least 3.1-fold (0.49 log units) from the limit.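

Compound 4 stands at a limit in this assay, as do compound 1, compound 2 and compound 3, and the steps from each of them to compound 4 cannot be read. The compounds shown leave open where each true half-maximal cytotoxic concentration lies, and whether exchanging the aromatic group changes it at all.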